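Swapping Trifluoromethyl for Bromo on a Shared Urea Core

A few compounds are considered here, and "the series" means these few. Any claim that something is new, unique, unknown or untested is made for them only; others in the source may bear on it.

Compound 1 `COc1cc(NC(=O)Nc2cc(Nc3ccc(C)c(F)c3)ncn2)cc(OC)c1` and compound 2 `COc1cc(NC(=O)Nc2cc(Nc3cc(C(F)(F)F)ccc3OC)ncn2)cc(OC)c1` share one core and were both run in a functional assay on PC-9 cells (Homo sapiens) for inhibition, read by MTT assay, with a stated time of 48 h, tested at 10 uM; on this read-out higher numbers stand for more inhibition at the one concentration tested (going by the name of the read-out) and lower numbers for less inhibition. Compound 1 gives 77.5%, and compound 2 gives 81.1%. Of the two numbers, compound 2 carries the nominally larger one, yet its gap to compound 1 falls within the scatter and so points to no real difference. Compound 3 `COc1cc(NC(=O)Nc2cc(Nc3cc(Br)ccc3OC)ncn2)cc(OC)c1` has not been measured; it differs from compound 2 by bromo in place of trifluoromethyl on an aromatic carbon. Among the compounds with values here, no measured step of this kind exists to lean on, so the expected change from compound 2 to compound 3 in this assay is a number 3.1 percentage points lower from compound 2 to compound 3 (within the scatter), nothing beyond the scatter. Compound 3 is accordingly estimated at 78% in this assay, between 60% and 92%.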

Compound 3, a percentage reported as inhibition, at one concentration (the size of the read-out at that concentration, not a potency): 82.5%
Beside the measured number, compound 3's estimate is 4.5 percentage points below it; the range from low to high includes it.
By their numbers in this assay, from the lowest: compounds 1, 2 and 3 (each within the scatter of the next).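

Bromo in place of trifluoromethyl gives a number 1.4 percentage points higher from compound 2 to compound 3 (within the scatter) in this assay at this aromatic carbon para to a methoxy group, so this swap shows no real difference here. Replacing the whole 3-fluoro-4-methylphenyl with 5-bromo-2-methoxyphenyl gives a number 5 percentage points higher from compound 1 to compound 3 (within the scatter) and likewise shows no real difference. Nothing available explains why these groups read alike.

Going by these compounds, whether an amine or a carboxylic acid at this aromatic carbon would keep the inhibition stays open. So does whether any change here moves it beyond the scatter.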